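Second fluoro on the benzyl group: clearance outlook

This account rests on a few compounds, and the source may have more. Where it says the series, first, only, none or still open, it means among the compounds named here.

Measured so far in an ADME assay on the whole organism (strain Sprague-Dawley) for pharmacokinetics, with Rattus norvegicus as the target, using cassette dosing; a lower number here means slower removal, a higher number faster removal of the compound:
compound 1 `O[C@]1(Cc2cc(-c3cn[nH]c3)on2)CC[C@H](Cc2ccccc2)CC1` gives 56.5 mL/min/kg
compound 2 `O[C@]1(Cc2cc(-c3cn[nH]c3)on2)CC[C@H](Cc2ccc(F)cc2)CC1` gives 30 mL/min/kg

Compound 2 has one measured neighbour, compound 1, and the two values lie within the scatter of each other. No ranking can be read from this pair.

Compound 3 `O[C@]1(Cc2cc(-c3cn[nH]c3)on2)CC[C@H](Cc2ccc(F)c(F)c2)CC1` keeps the shared core and has not yet been measured. The change from compound 2 is fluoro in place of hydrogen on an aromatic carbon, ortho to a fluoro group and meta to a large group. The same difference reads 4-fluorobenzyl to 3,4-difluorobenzyl.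

Going by the values given here, from a 1.9-fold lower number from compound 1 to compound 2 (0.27 log units; within the scatter), the only measured step of this kind and one within the scatter, a second replacement is expected to shift this assay by no more than the scatter, in no firm direction. A single step is thin evidence. The expected step is a 1.1-fold lower number from compound 2 to compound 3 (0.05 log units; within the scatter), which is no real change. For compound 3 the estimated value is 27 mL/min/kg, with an expected range from 13 mL/min/kg to 55 mL/min/kg.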

Compound 3, clearance: 15.2 mL/min/kg
Estimate against measurement, compound 3: 1.8-fold (0.25 log units) above, within the range that was stated.
By their numbers in this assay, from the lowest: compounds 3, 2 and 1 (each within the scatter of the next, the first and the last beyond it).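

In this assay, the second fluoro, ortho to a fluoro group and meta to a large group, gives a 2.0-fold lower number from compound 2 to compound 3 (0.30 log units; within the scatter), so this single step, like the first fluoro step, cannot be read as a real change on its own. Taken as one change on the saturated chain carbon, 3,4-difluorophenyl in place of phenyl gives a 3.7-fold lower number from compound 1 to compound 3 (0.57 log units; beyond the scatter), the only difference in this short series that lies beyond the scatter, and a modest one; the effect on clearance can therefore be read only for the two fluoro replacements together, not for either alone. No measurement is available that would explain this difference.

Still open, on these data alone, is whether the second fluoro would give a comparable step on the unsubstituted phenyl ring of compound 1, so the share of each fluoro in the total remains unknown. Also open, as far as these compounds go, is how a chlorine, a methoxy group or a nitrile on the same ring would compare with fluoro in this measure of clearance.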